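A few compounds are considered here, and "the series" means these few. Any claim that something is new, unique, unknown or untested is made for them only; others in the source may bear on it.

The series starts from compound 1 `Cc1cn(-c2csc(Nc3ccc(Br)cc3)n2)c(C)n1`, which in a functional assay on RKO cells (Homo sapiens) for cytotoxicity, read by resazurin assay, with a stated time of 72 h (on this read-out lower numbers stand for stronger inhibition and higher numbers for weaker inhibition), gives 45000 nM. Compound 2 `c1ccc(Nc2nc(-n3cnc4ccccc43)cs2)cc1` reports only a limit of the assay, > 100000 nM. Compound 3 `Cc1nccn1-c1csc(Nc2ccc(Br)cc2)n1` likewise reports only a limit, > 100000 nM, so its position on the numbers shown is an open-ended one, and it stands with compound 2 at the limit of > 100000 nM in this assay, at which 2 of the 3 values shown sit. For the measured compounds named here, the one measured step, an at least 2.2-fold higher number from compound 1 to compound 3 (0.34 log units; beyond the scatter), concerns hydrogen in place of methyl on an aromatic carbon and moves the number up to that limit.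

Compound 4 `Cc1ccc(Nc2nc(-n3ccnc3C)cs2)cc1` differs from compound 3 by methyl in place of bromo on an aromatic carbon. Going by the values given here, no measured step touches this position of the ring of carbon only; the single step seen concerns another site, so it offers no guide to direction or size here. Compound 4 is therefore expected to show a step that the limit leaves unreadable from compound 3 to compound 4, nothing beyond the scatter. Compound 4 is estimated at 120000 nM, within a range from 40000 nM to 400000 nM, and it may well again return only a limit.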

Compound 4, half-maximal inhibitory concentration: > 100000 nM
Compound 4 ended at the assay's limit; the forecaster's own chance of this, stated with the estimate: 70%; the middle value does not contradict the limit.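

Compound 3 and compound 4 both return only a limit in this assay, so no step can be read between them: the limit of > 100000 nM in this assay, at which 3 of the 4 values shown sit. The compounds shown leave open whether methyl in place of bromo on an aromatic carbon changes the number at all, and in which direction.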